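Aryl ether variation and cytotoxicity in the shared core

A few compounds are considered here, and "the series" means these few. Any claim that something is new, unique, unknown or untested is made for them only; others in the source may bear on it.

Compound 1 `COc1cccc(CNCCCNc2ccnc3cc(Oc4ccccc4)ccc23)c1O` and compound 2 `COc1cccc(CNCCCNc2ccnc3cc(Oc4cccc(N(C)C)c4)ccc23)c1O` share one core and differ only at the aryl ether. In an ADME assay on HepG2 cells (Homo sapiens) for cytotoxicity, read by luminescence, CellTiter-Glo and ATP content, with a stated time of 72 h (on this read-out higher numbers stand for an effect only at larger amounts of compound and lower numbers for an effect already at smaller amounts), compound 1 gives 6800 nM; in this assay compound 2 gives 7300 nM. For the measured compounds named here, the step of a 1.1-fold higher number from compound 1 to compound 2 (0.03 log units; within the scatter) stays within the scatter, so the two values carry no order between them, and compound 2 simply stands among the two numbers measured so far. Compound 3 `COc1cccc(CNCCCNc2ccnc3cc(Oc4ccc(C(C)(C)C)cc4)ccc23)c1O` is not yet measured; its change from compound 2 is 4-(tert-butyl)phenyl in place of 3-(dimethylamino)phenyl on an oxygen on an aromatic ring. Going by the values given here, only one measured step bears on this position, and it was flat, so a step beyond the scatter is not expected here either. The step of a 1.1-fold lower number from compound 2 to compound 3 (0.05 log units; within the scatter) is therefore estimated as flat. For compound 3 in this assay the expected value is 6500 nM, with a range from 3000 nM to 14000 nM.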

Compound 3, half-maximal effective concentration: 1500 nM
For compound 3 the middle estimate is 4.3-fold (0.64 log units) above the measured one; the measured number lies below the stated range.
By their numbers in this assay, from the lowest: compound 3; then compounds 1 and 2 (each within the scatter of the next).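

The aryl ether position is not flat in this assay: 4-(tert-butyl)phenyl in place of 3-(dimethylamino)phenyl gives a 4.9-fold lower number from compound 2 to compound 3 (0.69 log units; beyond the scatter) and so shows a step beyond the scatter, which the earlier dimethylamino change did not. Tert-butyl in place of hydrogen on an aromatic carbon gives a 4.5-fold lower number from compound 1 to compound 3 (0.66 log units; beyond the scatter) and points the same way, towards an effect already at smaller amounts of compound, so of the two substituents shown only tert-butyl separates from the plain phenyl ether. No measurement at hand accounts for this shift. The compounds shown leave open whether the shift follows the tert-butyl group itself or the place it occupies, since the two substituents carry different position numbers in their names. Also open, as far as these compounds go, is whether a smaller group such as methyl, or a halogen such as chlorine, on the same phenyl ring would give a step of similar size.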